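Chalcone hydrazones: ear inhibition, guanylhydrazone in place of isonicotinoyl

This account rests on a few compounds, and the source may have more. Where it says the series, first, only, none or still open, it means among the compounds named here.

Measured compounds, inhibition of the ear:
- compound 1, `N=C(N)N/N=C/c1ccc(/C=C/C(=O)c2cccc(Br)c2)cc1`: 49.7%
- compound 2, `Cc1ccc(C(=O)/C=C/c2ccc(/C=N/NC(=O)c3ccncc3)cc2)c(C)c1`: 58.5%
- compound 3, `O=C(/C=C/c1ccc(/C=N/NC(=O)c2ccncc2)cc1)c1ccc(Br)cc1`: 55.7%

Compound 3 stands second of the three numbers in a functional assay on the whole organism (Ear) for inhibition, with Mus musculus as the target, with a stated time of 30 min, at a dose of 100 mg/kg by the intraperitoneal route; a lower number here means less inhibition, a higher number more inhibition at the dose given (going by the name of the read-out). For the measured compounds named here, its nearest neighbour is compound 2, and the only step measured between two compounds differing in one place is a number 2.8 percentage points lower from compound 2 to compound 3 (within the scatter), a change on the carbonyl carbon that stays within the scatter. Compound 1, the furthest from compound 3, also lies within the scatter of it; the three measured values are therefore not ordered beyond noise.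

Compound 4, `N=C(N)N/N=C/c1ccc(/C=C/C(=O)c2ccc(Br)cc2)cc1`, is not yet measured. It differs from compound 3 in one place: a group of 3 heavy atoms (1 carbon, 2 nitrogen; no ring) in place of a group of 8 heavy atoms (6 carbon, 1 nitrogen, 1 oxygen; one six-membered aromatic ring with 1 hetero atom), on an amine nitrogen. Going by the values given here, the bromophenyl on the carbonyl carbon is kept, so the only change is the group on the amine nitrogen.

Among the compounds with values here, no measured step covers exactly this exchange. The closest guide is compound 1, which carries the same group entering in compound 4 together with a differently placed bromine on the carbonyl side. In this assay compound 1 gives 49.7%. Because a number 2.8 percentage points lower from compound 2 to compound 3 (within the scatter) shows the carbonyl-side aryl exchange changing little, compound 1 is taken as the model for compound 4. The step from compound 3 is therefore expected to be small, a number 5.7 percentage points lower from compound 3 to compound 4 (within the scatter), downward but within the scatter. For compound 4 the expected inhibition in this assay is 50%, estimated between 38% and 62%.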

Compound 4, a percentage reported as inhibition, in the whole organism at one dose (the size of the read-out at that dose, not a potency): 68.9%
Estimate against measurement, compound 4: 18.9 percentage points below; the whole stated range lies below it.
By their numbers in this assay, from the lowest: compounds 1, 3 and 2 (each within the scatter of the next); then compound 4.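

In this assay the group on the amine nitrogen matters: with the 4-bromophenyl kept, the group of 3 heavy atoms in place of (pyridin-4-yl)carbonyl gives a number 13.2 percentage points higher from compound 3 to compound 4 (beyond the scatter). For the compounds shown here, the carbonyl side also matters, at least with this amine nitrogen group, as 4-bromophenyl in place of 3-bromophenyl gives a number 19.2 percentage points higher from compound 1 to compound 4 (beyond the scatter), whereas the only earlier carbonyl-side step, a different aryl exchange with the (pyridin-4-yl)carbonyl group present, was a number 2.8 percentage points lower from compound 2 to compound 3 (within the scatter). No measurement bears on why either step arises.

The compounds shown leave open whether moving the bromine from the 3-position to the 4-position has the same effect with (pyridin-4-yl)carbonyl on the amine nitrogen, and whether the 2,4-dimethylphenyl group on the carbonyl carbon would hold up alongside the group of 3 heavy atoms. They also leave open how a different group on the amine nitrogen, such as a simple acetyl, would compare, and each value remains a reading at one dose rather than a potency.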